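Amino for methylsulfanyl on the indole-free notes: compound 4

The source may report more compounds than this note shows. Statements on the series, on what has been measured and on what is new or still open speak of the compounds shown alone.

PLACEHOLDER

That opening was a false start: its title names a ring system the data do not print, and it contains a placeholder. Please use the version below instead.

Amino for methylsulfanyl: working notes on compound 4

Values measured in a functional assay on A549 cells (Homo sapiens) for antiproliferative activity, read by MTT assay, with a stated time of 48 h (a higher number here means a weaker inhibitor, a lower number a stronger inhibitor), follow
compound 1 `COc1ccc2c(/C=C/C(=O)c3cc(N)c(OC)c(OC)c3)cn(C)c2c1` gives 106 nM
compound 2 `COc1ccc2c(/C=C/C(=O)c3cc(OC)c(OC)c(SC)c3)cn(C)c2c1` gives 156 nM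
compound 3 `COc1cc(C(=O)/C=C/c2cn(C)c3ccccc23)cc(SC)c1OC` gives 188 nM

Compound 3 stands at 188 nM in this assay and lies within the scatter of both other compounds. The next compound, compound 4 `COc1cc(C(=O)/C=C/c2cn(C)c3ccccc23)cc(N)c1OC`, carries amino in place of methylsulfanyl on an aromatic carbon and is not yet measured. The step bearing most directly on it is the same exchange in the opposite sense on the core of compound 1, where methylsulfanyl in place of amino gave a 1.5-fold higher number from compound 1 to compound 2 (0.17 log units; within the scatter) and stayed small. Among the compounds with values here, the other step, hydrogen in place of methoxy, gave a 1.2-fold higher number from compound 2 to compound 3 (0.08 log units; within the scatter) and concerns a different place, so it adds only that compound 3 remains a fair starting point. Reversing the first step on compound 3 gives an expected 1.4-fold lower number from compound 3 to compound 4 (0.16 log units; within the scatter) in this assay and no move beyond the scatter is expected. The estimate for compound 4 is 130 nM with an expected range from 60 nM to 280 nM for repeated measurements.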

Compound 4, half-maximal inhibitory concentration: 498 nM
The estimate for compound 4 lay 3.8-fold (0.58 log units) below the measured number; the measured number lies above the stated range.
By their numbers in this assay, from the lowest: compounds 1, 2 and 3 (each within the scatter of the next); then compound 4.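

In this assay, amino in place of methylsulfanyl gives a 2.6-fold higher number from compound 3 to compound 4 (0.42 log units; beyond the scatter), so on the core of compound 3 this position responds to the exchange beyond the scatter. The exchange therefore does not carry over unchanged from one core to the other: the same change on two cores in this assay, a 1.5-fold higher number (0.17 log units; within the scatter) from compound 1 to compound 2 and a 2.6-fold lower number (0.42 log units; beyond the scatter) from compound 4 to compound 3, 3.9-fold (0.59 log units) apart, beyond the scatter of two such steps. Hydrogen in place of methoxy, harmless with methylsulfanyl present, gives a 4.7-fold higher number from compound 1 to compound 4 (0.67 log units; beyond the scatter) with amino present, so among these four compounds the two places do not act independently: the same change on two cores in this assay, a 1.2-fold higher number (0.08 log units; within the scatter) from compound 2 to compound 3 and a 4.7-fold higher number (0.67 log units; beyond the scatter) from compound 1 to compound 4, 3.9-fold (0.59 log units) apart, beyond the scatter of two such steps.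

The compounds shown leave open whether the loss on the core of compound 3 is particular to amino or extends to other groups at this position, such as hydroxyl, dimethylamino or ethylsulfanyl. They also leave open whether fluorine or chlorine where the methoxy group was lost would give numbers closer to those of compound 1 or to those of compound 4.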